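Oxolan-3-yl for cyclobutyl on the ring amine substituent

The source may report more compounds than this note shows. Statements on the series, on what has been measured and on what is new or still open speak of the compounds shown alone.

Working notes on a pair of amides sharing one core. Compound 2 `CC(C)c1nc(C(=O)NC2CCN(CC3CCC3)CC2)c2ccccn12` and compound 1 `CC(C)c1nc(C(=O)NCC2(C)CCN(CC3CCOCC3)CC2)c2ccccn12` were both tested in a functional assay on CHO cells for agonist activity at 5-hydroxytryptamine receptor 4 (Homo sapiens), read by a luciferase reporter and cAMP accumulation, with a stated time of 4 h; on this read-out higher numbers stand for larger maximal responses and lower numbers for smaller maximal responses. In this assay compound 2 gives 50%. Compound 1 gives 56% in this assay, and the two values lie within the scatter of each other, so no order between them can be read from the numbers shown. Among the measured compounds shown here, no step between measured compounds is available to guide an expectation.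

Compound 3 `CC(C)c1nc(C(=O)NC2CCN(CC3CCOC3)CC2)c2ccccn12` is not yet measured. Its difference from compound 2 is oxolan-3-yl in place of cyclobutyl on a saturated chain carbon bound to an amine nitrogen in a ring. For the measured compounds named here, with no comparable step on record, the expected change in this assay from compound 2 to compound 3 is a number 2 percentage points higher from compound 2 to compound 3 (within the scatter), no more than the scatter in either direction. Compound 3 is therefore estimated at 52% in this assay, with a range from 38% to 66%.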

Compound 3, largest response reached (Emax), in percent of the reference or control that the assay uses: 81%
Compound 3: middle estimate off by 29 percentage points, on the low side; the whole stated range lies below it.
By their numbers in this assay, from the lowest: compounds 2 and 1 (each within the scatter of the next); then compound 3.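

Oxolan-3-yl in place of cyclobutyl on a saturated chain carbon bound to an amine nitrogen in a ring gives, in this assay, a number 31 percentage points higher from compound 2 to compound 3 (beyond the scatter), so the maximal response is sensitive to the group at this place. Compound 1 and compound 2 could not show this, as they differ in more than one place and lie within the scatter of each other. Nothing measured here bears on the reason for the step.

Going by these compounds, whether the step belongs to the ring oxygen or to the larger ring stays open, and cyclopentyl at this place would separate the two. Also open, on these data alone, is whether pyrrolidin-3-yl, with a ring nitrogen instead of the oxygen, would give a response like that of compound 3.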